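This account rests on a few compounds, and the source may have more. Where it says the series, first, only, none or still open, it means among the compounds named here.

Three compounds share one core and differ only in the group hung from the chain attached through the amine. Compound 1 `COc1ccc2c(c1)[n+]([O-])nc(NCOCc1ccccc1)[n+]2[O-]` gives 1190 nM in a functional assay on SMMC-7721 cells (Homo sapiens) for cytotoxicity, read by MTT assay, with a stated time of 72 h; a higher number here means a weaker inhibitor, a lower number a stronger inhibitor. Compound 2 `[O-][n+]1nc(NCOCc2ccccc2)[n+]([O-])c2ccccc21` gives 4790 nM in this assay, the highest of the three numbers. Compound 3 `CC(OCNc1n[n+]([O-])c2ccccc2[n+]1[O-])c1ccccc1` gives 2470 nM in this assay. The step of a 4.0-fold higher number from compound 1 to compound 2 (0.60 log units; beyond the scatter) sets compound 2 furthest from compound 1, while the step of a 1.9-fold lower number from compound 2 to compound 3 (0.29 log units; within the scatter) leaves compound 3 nearest to it.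

Compound 4 `CC(C)CCOCNc1n[n+]([O-])c2ccccc2[n+]1[O-]` is not yet measured. It differs from compound 2 by isobutyl in place of phenyl on a saturated chain carbon bound to an oxygen on a saturated carbon. Within the data shown here, of the measured steps, the one from compound 2 to compound 3 bears most directly on this change, since it also alters the chain beyond the oxygen, and it stayed small. The step from compound 1 to compound 2 changes the core instead and says little here. The expectation for this assay is therefore a step of modest size at most, in either direction, and the estimated step is a 1.2-fold lower number from compound 2 to compound 4 (0.08 log units; within the scatter). Compound 4 is expected to give about 4000 nM, within a range from 1500 nM to 12000 nM.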

Compound 4, half-maximal inhibitory concentration: 2860 nM
Compound 4: the middle estimate sits 1.4-fold (0.15 log units) above what was measured, within the range that was stated.
By their numbers in this assay, from the lowest: compound 1; then compounds 3, 4 and 2 (each within the scatter of the next).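

All three earlier compounds end their chain in an aromatic ring, so they could not show whether that ring is needed for activity. In this assay the exchange of phenyl for isobutyl on a saturated chain carbon bound to an oxygen on a saturated carbon removes that ring and gives a 1.7-fold lower number from compound 2 to compound 4 (0.22 log units; within the scatter) and so, for this pair, an open-chain group serves within the scatter of the ring-bearing one. No measurement at hand gives a reason for this result. From the compounds shown here alone, what remains open is whether the methoxy group on the core of compound 1 would also shift the number for a compound carrying the isobutyl group. Also open, going by these compounds, is how the number would respond at this position to a longer chain, or to a chain ending in an amine or a carboxylic acid.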